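Methoxy-to-nitrile swap on the aryl ether: working notes

This account rests on a few compounds, and the source may have more. Where it says the series, first, only, none or still open, it means among the compounds named here.

Measured so far in a functional assay on cells for antagonist activity at Free fatty acid receptor 1 (Homo sapiens), read by TR-FRET and inositol phosphate accumulation, with a stated time of 2 h; on this read-out lower numbers stand for stronger inhibition and higher numbers for weaker inhibition:
compound 1 `COc1ccccc1OCc1cc(C)nc(-c2ccccn2)n1` gives 2000 nM
compound 2 `COc1ccc(OCc2cc(C)nc(-c3ccccn3)n2)cc1` gives 7940 nM
compound 3 `Cc1cc(COc2ccccc2C#N)nc(-c2ccccn2)n1` gives 10000 nM

Compound 1 and compound 2 are built from the same atoms joined differently; the difference between the two cores is not broken down here. Compound 3 arises from compound 1 by cyano in place of methoxy on an aromatic carbon; this step gives a 5.0-fold higher number from compound 1 to compound 3 (0.70 log units; beyond the scatter). The value of compound 2 lies within the scatter of that of compound 3, so no order between those two is claimed, while compound 2 and compound 1 are separated beyond the scatter.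

Compound 4 `Cc1cc(COc2ccc(C#N)cc2)nc(-c2ccccn2)n1` is not yet measured. It arises from compound 2 by cyano in place of methoxy on an aromatic carbon. Among the compounds with values here, this is the same kind of change as the one from compound 1 to compound 3, not the same: in compound 4 the group sits para to a large group, whereas in compound 3 it sits ortho to a large group. Within the data shown here, only one such step has been measured, so the expectation for compound 4 rests on that single pair. If the change behaves as it did between compound 1 and compound 3, compound 4 is expected to give a higher number than compound 2, and the estimated step is a 3.1-fold higher number from compound 2 to compound 4 (0.50 log units; beyond the scatter). The estimate for compound 4 in this assay is 25000 nM, expected to fall between 8000 nM and 80000 nM. Among the measured compounds shown here, compound 3 sits at 10000 nM, the highest number measured so far, and the upper end of the range given for compound 4 lies beyond it.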

Compound 4, half-maximal inhibitory concentration: 31600 nM
Estimate against measurement, compound 4: 1.3-fold (0.10 log units) below; measured number inside the range.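

In this assay, cyano in place of methoxy, para to a large group, gives a 4.0-fold higher number from compound 2 to compound 4 (0.60 log units; beyond the scatter). Set beside the earlier step, the change carries from one core to the other with the same direction and no size difference that can be told apart: the same change on two cores in this assay, a 5.0-fold higher number (0.70 log units; beyond the scatter) from compound 1 to compound 3 and a 4.0-fold higher number (0.60 log units; beyond the scatter) from compound 2 to compound 4, 1.3-fold (0.10 log units) apart, within the scatter of two such steps

This shows that, for these two pairs, the nitrile gives the higher number in both placements of the group on the aryl ether, and that one pair predicts the other reasonably well; it does not show that the step would hold on any further core, and two pairs give no account of why the numbers rise.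

Still open, going by these compounds, is whether any other replacement of methoxy on the aryl ether, such as an amine, a carboxylic acid or a longer alkoxy chain, would give a number lower than that of compound 1 at 2000 nM rather than higher. All four compounds also share the same methyl group on the core, so whether the step keeps its size when a longer chain stands in place of that methyl remains an untested question for the series.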